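Swapping a Side Chain for an Oxane Ring

This account rests on a few compounds, and the source may have more. Where it says the series, first, only, none or still open, it means among the compounds named here.

Among the measured compounds shown here, in a functional assay on HeLa cells (Homo sapiens) for cytotoxicity, read by MTT assay (a lower number here means a stronger inhibitor, a higher number a weaker inhibitor), compound 2 `CCCCC(C)(O)CC(=O)O[C@H](CC=C(C)C)C1=CC(=O)c2c(O)ccc(O)c2C1=O` gives 60600 nM, the only actual number so far. Compound 1 `CC(C)=CC[C@@H](OC(=O)C1CCCCO1)C1=CC(=O)c2c(O)ccc(O)c2C1=O` gives > 100000 nM, which is a limit of the assay and not a number.

Compound 3 `CC(C)=CC[C@@H](OC(=O)C1CCCOC1)C1=CC(=O)c2c(O)ccc(O)c2C1=O` remains unmeasured. It differs from compound 2 as follows: oxan-3-yl in place of 2-hydroxy-2-methylhexyl on a carbonyl carbon. That puts oxan-3-yl in place of 2-hydroxy-2-methylhexyl on a carbonyl carbon.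

For the measured compounds named here, only one measured step bears on this: an at least 1.6-fold lower number from compound 1 to compound 2 (0.21 log units; that floor lies within the scatter), which put 2-hydroxy-2-methylhexyl in place of oxan-2-yl. On these data alone, the full size of that step stays open for compound 1 because of the limit of > 100000 nM in this assay, at which 1 of the 2 values shown sits. Read in reverse, it suggests a small move towards a higher number, probably none beyond the scatter.

The estimated change is a 1.7-fold higher number from compound 2 to compound 3 (0.22 log units; within the scatter). For compound 3, the expected value is 100000 nM, with an estimated range of 50000 nM to 200000 nM.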

Compound 3, half-maximal inhibitory concentration: 60500 nM
The estimate for compound 3 lay 1.7-fold (0.22 log units) above the measured number; the measured number falls inside the stated range.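

In this assay, oxan-3-yl can stand on the carbonyl carbon in place of 2-hydroxy-2-methylhexyl with no visible effect, a ring replacing an open chain and the chain's hydrogen-bond donor disappearing: the result is a 1.0-fold lower number from compound 2 to compound 3 (0.00 log units; within the scatter). Comparing the two rings, oxan-3-yl in place of oxan-2-yl gives an at least 1.6-fold lower number from compound 1 to compound 3 (0.21 log units; that floor lies within the scatter). Compound 1 gives > 100000 nM, which is a limit of the assay and not a number, so the full size of that step stays unknown: the limit of > 100000 nM in this assay, at which 1 of the 3 values shown sits.

Still open, on these data alone, is whether an amine or a carboxylic acid in this place would move the number beyond the scatter. Also open, as far as these compounds go, is whether a longer chain without the hydroxyl group would behave like 2-hydroxy-2-methylhexyl.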